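Adding a Methyl to Compound 2: Expected Clearance

The compounds below may be only part of what the source reports. "The series", "measured", "known", "first", "only" and "open" are said of these compounds alone.

Compound 1, `Cc1cc(N(C)C(N)=O)cc(C)c1CCS(=O)(=O)N1CCC2(CC1)N=C([C@H]1CC[C@H](C)CC1)NC2=O`: compound 1 gives 45 uL/min in an ADME assay on microsomes from liver (Homo sapiens) for metabolic stability, read by LC-MS, using NADPH, with a stated time of 30 min, tested at 1 uM; on this read-out higher numbers stand for fast clearance and lower numbers for slow clearance.
Compound 2, `CC(=O)Nc1ccc(CCS(=O)(=O)N2CCC3(CC2)N=C(C2CCCCC2)NC3=O)c(C)c1`: compound 2 gives 46 uL/min in this assay.
Compound 3, `Cc1cc(N2CCNC2=O)cc(C)c1CCS(=O)(=O)N1CCC2(CC1)N=C(C1CCCCC1)NC2=O`: compound 3 gives 62 uL/min in this assay.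

Of the compounds shown here, three sharing one core have been measured in this assay. Compound 2 stands second highest of the three numbers. Its nearest neighbour is compound 1, whose number sits within the usual scatter of that of compound 2; its furthest is compound 3, and that gap too lies within the scatter. Taken together, the three numbers show no separation that can be trusted, so nothing is yet known about how a change on the aromatic ring moves the read-out.

Compound 4, `CC(=O)Nc1cc(C)c(CCS(=O)(=O)N2CCC3(CC2)N=C(C2CCCCC2)NC3=O)c(C)c1`, is not yet measured. It differs from compound 2 in one place: methyl in place of hydrogen on an aromatic carbon. The new methyl sits on an aromatic carbon of the six-membered aromatic ring of carbon only, meta to an acetamido group and meta to a methyl group.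

Within the data shown here, the measured numbers give no step to lean on; the expectation for compound 4 rests on the likeness of its core to that of compound 2, which gives 46 uL/min in this assay. The step from compound 2 to compound 4 is expected to be small, a 1.1-fold higher number from compound 2 to compound 4 (0.04 log units; within the scatter), and to stay within the scatter. Compound 4 is therefore estimated at 50 uL/min, with a range from 25 uL/min to 100 uL/min.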

Compound 4, intrinsic clearance in a liver preparation (reported as CLH), per the amount of preparation that the assay uses in the Homo sapiens assay: 39 uL/min
Compound 4: the middle estimate sits 1.3-fold (0.11 log units) above what was measured; the range from low to high includes it.
By their numbers in the Homo sapiens assay, from the lowest: compounds 4, 1, 2 and 3 (each within the scatter of the next).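

In the Homo sapiens assay a methyl at this place, on an aromatic carbon ortho to a large group, leaves the number within the scatter, a 1.2-fold lower number from compound 2 to compound 4 (0.07 log units; within the scatter), and the exchange of 2-oxoimidazolidin-1-yl for acetamido does the same, a 1.6-fold lower number from compound 3 to compound 4 (0.20 log units; within the scatter). The earlier compounds shown here gave no single-place step for this read-out, and these two steps still separate no compound on clearance. What sets this pair apart appears on another read-out, where in a physicochemical assay for solubility, read by HPLC, in phosphate buffer, at pH 6.5, tested at 1 mM (on this read-out higher numbers stand for higher solubility and lower numbers for lower solubility), compound 2 gives 280 ug/mL and compound 4 gives 8 ug/mL, so that in this pair the one added methyl goes with a large loss of solubility and no clear change in clearance: the measured solubility of compound 2, 280 ug/mL, and of compound 4, 8 ug/mL, a 35-fold lower number (1.54 log units; beyond the scatter)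

From the compounds shown here alone, it remains open whether a fluorine atom, a methoxy group or an aminomethyl group on the same aromatic carbon would give a similar number for clearance with a smaller loss of solubility. The compounds shown also leave open whether the methyl would give the same solubility step with a 2-oxoimidazolidin-1-yl group on the ring in place of the acetamido group.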